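The source may report more compounds than this note shows. Statements on the series, on what has been measured and on what is new or still open speak of the compounds shown alone.

Compound 1, with structure `COC(=O)[C@@]1(C)CCC=C2[C@@H]1CC[C@@H](C)[C@]2(C)Cc1c(C)[nH]c2ccc(Br)cc12`, and compound 2, with structure `COC(=O)[C@@]1(C)CCC=C2[C@@H]1CC[C@@H](C)[C@]2(C)Cc1c(C)[nH]c2ccc(Cl)cc12`, share one core, while compound 3, with structure `COC(=O)[C@@]1(C)CC[C@@H]2C3=C1CC[C@@H](C)[C@]3(C)C[C@@H]1c3cc(Br)ccc3N[C@H]21`, and the as yet unmeasured compound 4, with structure `COC(=O)[C@@]1(C)CC[C@@H]2C3=C1CC[C@@H](C)[C@]3(C)C[C@@H]1c3cc(Cl)ccc3N[C@H]21`, share another. In a functional assay on HBL-100 cells (Homo sapiens) for inhibition, read by sulforhodamine B assay, with a stated time of 48 h (a higher number here means a weaker inhibitor of growth, a lower number a stronger inhibitor of growth), compound 1 gives 15000 nM, and in this assay compound 2 gives 15000 nM. For the measured compounds named here, the single change between them, (chloro in place of bromo on an aromatic carbon), made the step of no change at the digits printed from compound 1 to compound 2 (within the scatter). In this assay compound 3 gives 34000 nM, the highest of the three numbers; how its core differs from that of compound 1 is not broken down here. Compound 4 arises from compound 3 by chloro in place of bromo on an aromatic carbon, the same kind of change as in the first pair, though here the aromatic carbon belongs to a fused or bridged system of five rings rather than two. Since the earlier step of no change at the digits printed from compound 1 to compound 2 (within the scatter) was within the scatter, the step from compound 3 to compound 4 is expected to be no change at the digits printed from compound 3 to compound 4 (within the scatter). On that basis compound 4 is estimated at 34000 nM, with a range from 17000 nM to 68000 nM.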

Compound 4, concentration for 50% growth inhibition: 28000 nM
For compound 4 the middle estimate is 1.2-fold (0.08 log units) above the measured one; low and high end bracket the measured number.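

In this assay, the step on the second core, a 1.2-fold lower number from compound 3 to compound 4 (0.08 log units; within the scatter), agrees with the step on the first core: the same change on two cores in this assay, no change at the digits printed (within the scatter) from compound 1 to compound 2 and a 1.2-fold lower number (0.08 log units; within the scatter) from compound 3 to compound 4, 1.2-fold (0.08 log units) apart, within the scatter of two such steps. Within these two pairs, then, chloro in place of bromo carried from one core to the other with no step beyond the scatter, and the two groups could not be told apart on either core. For the compounds shown here, this rests on only two pairs in a single assay, and since neither step is distinguishable from scatter, it does not show whether either core would alter a larger effect or whether any other change would carry across in the same way.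

From the compounds shown here alone, all four compounds carry bromo or chloro on that aromatic carbon, so it remains open whether fluoro, methoxy or an amine there would shift growth inhibition on either core, and whether such a step would match between the cores. All four also keep the methyl ester, which leaves open what a carboxylic acid or an amide in its place would do.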